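Adding a Fluorine to the Bridging Ring of Compound 3

The source may report more compounds than this note shows. Statements on the series, on what has been measured and on what is new or still open speak of the compounds shown alone.

Three compounds share one core and differ only in the halogen on the pendant ring. In a functional assay on MCF7 cells (Homo sapiens) for cytotoxicity, read by MTT assay, with a stated time of 72 h (a lower number here means a stronger inhibitor, a higher number a weaker inhibitor), compound 1 `O=C(Nc1ccc(Oc2ccnc3[nH]ccc23)cc1)c1cc(-c2ccc(F)cc2)ncn1` gives 15900 nM. Compound 2 `O=C(Nc1ccc(Oc2ccnc3[nH]ccc23)cc1)c1cc(-c2ccc(Cl)cc2)ncn1` gives 7770 nM in this assay, and compound 3 `O=C(Nc1ccc(Oc2ccnc3[nH]ccc23)cc1)c1cc(-c2ccc(Br)cc2)ncn1` gives 3840 nM, the lowest of the three numbers. The steps were a 2.0-fold lower number from compound 1 to compound 2 (0.31 log units; beyond the scatter), a 2.0-fold lower number from compound 2 to compound 3 (0.31 log units; beyond the scatter), and overall a 4.1-fold lower number from compound 1 to compound 3 (0.62 log units; beyond the scatter).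

Compound 4 `O=C(Nc1ccc(Oc2ccnc3[nH]ccc23)c(F)c1)c1cc(-c2ccc(Br)cc2)ncn1` keeps the bromo of compound 3 and alters the other ring: fluoro in place of hydrogen on an aromatic carbon, at a carbon ortho to a large group and meta to a large group. For the measured compounds named here, no measured step is of this kind; the three steps all swapped one halogen for another on the distant ring, and each was modest. They show only that single-atom edits on this core have moved the numbers by modest amounts. Going by the values given here, with no direct precedent, the step is expected to be a 1.1-fold lower number from compound 3 to compound 4 (0.04 log units; within the scatter), within the scatter. Compound 4 is therefore estimated at 3500 nM, with a range from 1400 nM to 9000 nM.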

Compound 4, half-maximal inhibitory concentration: 10300 nM
Beside the measured number, compound 4's estimate is 2.9-fold (0.47 log units) below it; the measured number lies above the stated range.
By their numbers in this assay, from the lowest: compound 3; then compounds 2, 4 and 1 (each within the scatter of the next, the first and the last beyond it).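

Until this point only the halogen on the pendant ring had changed, and each swap lowered the number. The first edit on the bridging ring, fluoro in place of hydrogen at a carbon ortho to a large group and meta to a large group, goes the other way in this assay, with a 2.7-fold higher number from compound 3 to compound 4 (0.43 log units; beyond the scatter), so a single added atom at this carbon moves the number beyond the scatter, and the trend seen on the pendant ring does not carry over to this ring. Nothing measured here explains the rise.

A chloro, methyl or methoxy group at this same carbon would show whether the rise is particular to fluoro or comes with any group placed there. On these data alone, whether fluoro here has the same effect alongside a chloro on the pendant ring also remains open.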